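The source may hold more compounds than are shown below. What is called first, only, known or untested is meant among the compounds shown, and "the series" means these compounds.

Measured in a functional assay on MDA-MB-435 cells (Homo sapiens) for inhibition, read by sulforhodamine B assay, with a stated time of 48 h; on this read-out lower numbers stand for stronger inhibition and higher numbers for weaker inhibition:
Compound 1 `O=C(Nc1cccc(-n2cc(-c3ccncc3)c(-c3ccc(Cl)c(O)c3)n2)c1)Nc1cccc(C(F)(F)F)c1` gives 1490 nM.
Compound 2 `COc1cc(-c2nn(-c3cccc(NC(=O)Nc4cc(C(F)(F)F)cc(C(F)(F)F)c4)c3)cc2-c2ccncc2)ccc1Cl` gives 890 nM.
Compound 3 `COc1cc(-c2nn(-c3cccc(NC(=O)c4cccc(C(F)(F)F)c4)c3)cc2-c2ccncc2)ccc1Cl` gives 710 nM.

Among these three numbers, compound 3 holds the lowest. Compound 2 sits close to it, within the usual scatter, so the two cannot be ordered against each other. Compound 1 lies further off, beyond the scatter, and is the only one of the three that is clearly weaker than compound 3 in this assay.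

Compound 4 `COc1cc(-c2nn(-c3cccc(NC(=O)c4ccc(Cl)c(C(F)(F)F)c4)c3)cc2-c2ccncc2)ccc1Cl` has not yet been measured. It differs from compound 3 in one place: chloro in place of hydrogen on an aromatic carbon. Going by the values given here, no pair of measured compounds differs by this kind of change, so nothing here shows how large such a step tends to be. The step is expected to be of modest size, a 1.2-fold lower number from compound 3 to compound 4 (0.07 log units; within the scatter), most likely within the scatter and without a clear direction. Compound 4 is therefore estimated at 600 nM in this assay, within a range from 220 nM to 1600 nM.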

Compound 4, half-maximal inhibitory concentration: 660 nM
Estimate against measurement, compound 4: 1.1-fold (0.04 log units) below; the measured number falls inside the stated range.
By their numbers in this assay, from the lowest: compounds 4, 3, 2 and 1 (each within the scatter of the next, the first and the last beyond it).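

The step of a 1.1-fold lower number from compound 3 to compound 4 (0.03 log units; within the scatter) in this assay is the only single-place comparison among the compounds shown, and it lies within the scatter, so compound 3 and compound 4 cannot be told apart. It shows that going from 3-(trifluoromethyl)phenyl to 4-chloro-3-(trifluoromethyl)phenyl, with chloro ortho to the trifluoromethyl group and para to a large group, leaves no readable difference on this read-out. No measurement offered here bears on what lies behind this result.

The compounds shown leave open whether a larger or different group at this carbon, such as an amine, a carboxylic acid or a methoxy group, would give a step beyond the scatter. They also leave open whether the same chloro step would read alike in the setting of compound 2, which carries a different linker and ring substitution.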